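Amide substituent change in the shared core: compound 3

This account rests on a few compounds, and the source may have more. Where it says the series, first, only, none or still open, it means among the compounds named here.

Compound 1 `O=C(Nc1ccccc1)c1c(O)c2cccnc2n(-c2ccccc2)c1=O` in a functional assay on the whole organism for inhibition, with Rattus norvegicus as the target, read by cytopathic effect and paw edema, at a dose of 100 mg/kg by the oral route (a higher number here means more inhibition at the dose given (going by the name of the read-out), a lower number less inhibition), gives -15%.
Compound 2 `COc1cccc(NC(=O)c2c(O)c3cccnc3n(-c3ccccc3)c2=O)c1` in this assay gives 20.7%.

Among the compounds with values here, compound 2 stands highest of the two numbers so far; its only neighbour is compound 1, and the single measured step is a number 35.7 percentage points higher from compound 1 to compound 2 (beyond the scatter), a gain beyond the scatter for methoxy in place of hydrogen on an aromatic carbon.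

Compound 3 `O=C(Nc1ccncc1)c1c(O)c2cccnc2n(-c2ccccc2)c1=O` is still to be measured in this assay. It differs from compound 2 by pyridin-4-yl in place of 3-methoxyphenyl on an amide-type nitrogen. The step from compound 1 to compound 2 bears on this: the one gain seen came with the methoxy, and compound 3 carries no methoxy. Within the data shown here, no measured step shows what pyridin-4-yl does in place of a carbon-only ring on the amide-type nitrogen, so that part of the change is unknown. The expectation is therefore a fall that roughly undoes the earlier gain, with a wide range. Compound 3 is expected to show a number 22.7 percentage points lower from compound 2 to compound 3 (beyond the scatter). The estimate for compound 3 is -2%, within -22% to 18%.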

Compound 3, a percentage reported as inhibition, in the whole organism at one dose (the size of the read-out at that dose, not a potency): 24.3%
Estimate against measurement, compound 3: 26.3 percentage points below; measured number outside the range, above it.
By their numbers in this assay, from the lowest: compound 1; then compounds 2 and 3 (each within the scatter of the next).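

In this assay the rise over the phenyl amide turns out not to need a methoxy: there is a number 39.3 percentage points higher from compound 1 to compound 3 (beyond the scatter) with pyridin-4-yl in place of phenyl on the amide-type nitrogen, so a ring with a hetero atom and no methoxy also carries it at this position. Exchanging the two substituted rings gives a number 3.6 percentage points higher from compound 2 to compound 3 (within the scatter) and, being within the scatter, leaves 3-methoxyphenyl and pyridin-4-yl unranked, even though they differ in ring type and heavy-atom count and share the one hydrogen-bond acceptor counted for each. Nothing at hand explains why either group differs from phenyl in this read-out.

The compounds shown leave open whether the placing of the ring nitrogen matters, as pyridin-3-yl or pyridin-2-yl on the same amide-type nitrogen would show, and whether the ring must be aromatic at all, as a piperidin-4-yl group would test. They also leave open how far a group such as an amine or a carboxylic acid on the phenyl ring would be accepted, and all these numbers describe a single oral dose, so they give no potency.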